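Swapping a bromobenzyl chain for octyl on the triazole

The source may report more compounds than this note shows. Statements on the series, on what has been measured and on what is new or still open speak of the compounds shown alone.

Measured so far:
- Compound 1, `CCCCCCCCn1cc(/C=C/C(=O)c2ccc(NC(=O)CN3CCN(c4ccccc4F)CC3)cc2)nn1`: 47100 nM
- Compound 2, `COc1ccccc1N1CCN(CC(=O)Nc2ccc(C(=O)/C=C/c3cn(Cc4ccc(Br)cc4)nn3)cc2)CC1`: 34000 nM

Both compounds were tested in a functional assay on A549 cells (Homo sapiens) for inhibition, read by MTT assay; on this read-out lower numbers stand for stronger inhibition and higher numbers for weaker inhibition. Compound 1 gives 47100 nM and compound 2 gives 34000 nM; the gap between them lies within the usual scatter of repeated measurements, so neither can be called the stronger inhibitor. Compound 3, `CCCCCCCCn1cc(/C=C/C(=O)c2ccc(NC(=O)CN3CCN(c4ccccc4OC)CC3)cc2)nn1`, has not yet been measured. It differs from compound 2 in one place: heptyl in place of 4-bromophenyl on a saturated chain carbon bound to an aromatic nitrogen. Compound 3 thus carries the octyl chain seen in compound 1 together with the methoxyphenyl piperazine of compound 2. For the measured compounds named here, with only two measured values, both weak and close together, there is no measured step to lean on, and the expectation is a change no larger than the scatter in either direction. For compound 3 the estimated step is a 1.2-fold higher number from compound 2 to compound 3 (0.07 log units; within the scatter), and the expected value is 40000 nM with a range from 15000 nM to 110000 nM in this assay.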

Compound 3, half-maximal inhibitory concentration: 34000 nM
Compound 3: the middle estimate sits 1.2-fold (0.07 log units) above what was measured, within the range that was stated.
By their numbers in this assay, from the lowest: compounds 2, 3 and 1 (each within the scatter of the next).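

At the saturated chain carbon bound to an aromatic nitrogen, heptyl in place of 4-bromophenyl reads as no change at the digits printed from compound 2 to compound 3 (within the scatter) in this assay, so a ring carrying bromine and an open chain cannot be told apart at this position. Methoxy in place of fluoro on an aromatic carbon, now readable as a single change, reads as a 1.4-fold lower number from compound 1 to compound 3 (0.14 log units; within the scatter), so this swap also stays inside the noise of the measurement. Nothing on hand explains either result.

Going by these compounds, whether any change at these two places can move the number beyond the scatter stays open. A heptyl chain ending in an amine or a carboxylic acid, or a simple methyl in its place, could test this at the first position, and a chlorine or a hydroxyl group could test it at the second.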